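This account rests on a few compounds, and the source may have more. Where it says the series, first, only, none or still open, it means among the compounds named here.

Compound 3 `Cc1cc(NC(=O)CC2CCCCC2)nn1Cc1cc(Cl)ccc1OCc1ccccc1` gives the lowest number of the three in an assay on CHO-K1 cells for displacement of a labelled ligand from prostaglandin E2 receptor EP1 subtype (Homo sapiens) (a lower number here means a stronger inhibitor, a higher number a weaker inhibitor), at 6.31 nM. Compound 2 `Cc1cc(NC(=O)CC(C)(C)C)nn1Cc1cc(Cl)ccc1OCc1ccccc1`, with 10 nM, sits close: a 1.6-fold lower number from compound 2 to compound 3 (0.20 log units; within the scatter). Compound 1 `CC(=O)Nc1cc(C)n(Cc2cc(Cl)ccc2OCc2ccccc2)n1`, with 316 nM, stands far off: a 50-fold lower number from compound 1 to compound 3 (1.70 log units; beyond the scatter) and a 32-fold lower number from compound 1 to compound 2 (1.50 log units; beyond the scatter). Compound 4 `Cc1cc(NC(=O)OC(C)(C)C)nn1Cc1cc(Cl)ccc1OCc1ccccc1` carries tert-butoxy in place of cyclohexylmethyl on a carbonyl carbon. Within the data shown here, the step from tert-butyl to cyclohexyl on the chain carbon, between compound 2 and compound 3, stayed within the scatter, and both were far from compound 1, so a branched group on the carbonyl side appears to carry most of the gain; the oxygen now entering has no measured counterpart. Compound 4 is therefore expected at 20 nM, between 6 nM and 63 nM, a step estimated as a 3.2-fold higher number from compound 3 to compound 4 (0.50 log units; beyond the scatter).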

Compound 4, half-maximal inhibitory concentration: 25.1 nM
Estimate against measurement, compound 4: 1.3-fold (0.10 log units) below, and the stated range covers the measured number.
By their numbers in this assay, from the lowest: compounds 3 and 2 (each within the scatter of the next); then compound 4; then compound 1.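

In this assay, among these compounds, tert-butoxy on the carbonyl carbon separates from both carbon-linked groups, a difference the earlier compounds did not show (a 4.0-fold higher number from compound 3 to compound 4 (0.60 log units; beyond the scatter); a 2.5-fold higher number from compound 2 to compound 4 (0.40 log units; beyond the scatter)). Even so, it retains much of the gain over methyl (a 13-fold lower number from compound 1 to compound 4 (1.10 log units; beyond the scatter)). No available evidence bears on the reason for these steps. Still open, from the compounds shown here alone, is whether the loss goes with the oxygen itself or with the change of group as a whole: a cyclohexyloxy or tert-butylamino group on the same carbonyl carbon would help separate these.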